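The source may hold more compounds than are shown below. What is called first, only, known or untested is meant among the compounds shown, and "the series" means these compounds.

Measured in a functional assay on A549 cells (Homo sapiens) for antiproliferative activity, read by MTT assay, with a stated time of 72 h; on this read-out lower numbers stand for stronger inhibition and higher numbers for weaker inhibition:
- compound 1 `COc1cc(C(=O)c2sc3ccccc3c2Nc2ccc(C)cc2)cc(OC)c1OC`: 2600 nM
- compound 2 `CCOc1ccc(Nc2c(C(=O)c3cc(OC)c(OC)c(OC)c3)sc3ccccc23)cc1`: 1400 nM
- compound 3 `COc1cc(C(=O)c2sc3cc(C)ccc3c2Nc2ccc(C)cc2)cc(OC)c1OC`: 1900 nM

In this assay, compound 3 gives 1900 nM, in the same range as the other two compounds, since its gaps to both lie within the scatter. The next compound, compound 4 `CCOc1ccc(Nc2c(C(=O)c3cc(OC)c(OC)c(OC)c3)sc3cc(C)ccc23)cc1`, has ethoxy in place of methyl on an aromatic carbon of a six-membered aromatic ring of carbon only, para to a large group: ethoxy in place of methyl on an aromatic carbon.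

For the measured compounds named here, the closest precedent is the same swap made without the extra methyl on the core, a 1.9-fold lower number from compound 1 to compound 2 (0.27 log units; within the scatter). Adding that methyl gave a 1.4-fold lower number from compound 1 to compound 3 (0.14 log units; within the scatter), so it offers no sign that the swap should behave differently in compound 4. Both steps are small, so only a modest move towards a lower number is expected, and it may not be distinguishable from the scatter. The expected change is a 1.7-fold lower number from compound 3 to compound 4 (0.24 log units; within the scatter).

For compound 4 the estimated value is 1100 nM, with an expected range from 550 nM to 2200 nM.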

Compound 4, half-maximal inhibitory concentration: 5800 nM
The estimate for compound 4 lay 5.3-fold (0.72 log units) below the measured number; measured number above the stated range.
By their numbers in this assay, from the lowest: compounds 2, 3 and 1 (each within the scatter of the next); then compound 4.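

The swap from 4-methylphenyl to 4-ethoxyphenyl does not carry over from one core to the other: on the core with the extra methyl it gives a 3.1-fold higher number from compound 3 to compound 4 (0.48 log units; beyond the scatter). In this assay, the effect of a change at this position therefore depends on what else the core carries, and the two changes do not simply add up: the same change on two cores in this assay, a 1.9-fold lower number (0.27 log units; within the scatter) from compound 1 to compound 2 and a 3.1-fold higher number (0.48 log units; beyond the scatter) from compound 3 to compound 4, 5.7-fold (0.75 log units) apart, beyond the scatter of two such steps. Read the other way, the core methyl leaves compounds 1 and 3 within the scatter of each other, yet it gives a 4.1-fold higher number from compound 2 to compound 4 (0.62 log units; beyond the scatter): the same change on two cores in this assay, a 1.4-fold lower number (0.14 log units; within the scatter) from compound 1 to compound 3 and a 4.1-fold higher number (0.62 log units; beyond the scatter) from compound 2 to compound 4, 5.7-fold (0.75 log units) apart, beyond the scatter of two such steps.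

The compounds shown give no reason for this dependence, since they hold only one pair of cores and one swap. Going by these compounds, it remains open whether methoxy, a longer propoxy chain or an amine in this place on the methyl-bearing core would follow ethoxy or methyl.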